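Compound 3 Expected to Stay Close to Compound 2

The source may hold more compounds than are shown below. What is called first, only, known or untested is meant among the compounds shown, and "the series" means these compounds.

Compound 1 `COc1ccc(-c2ccc3c(c2)C(=O)C(=O)N3c2ccc(OC)cc2)cc1` — in a functional assay on K562 cells (Homo sapiens) for antiproliferative activity, read by MTT assay, with a stated time of 48 h (a lower number here means a stronger inhibitor, a higher number a weaker inhibitor), a limit only: > 10000 nM.
Compound 2 `COc1ccc(CN2C(=O)C(=O)c3cc(-c4ccc(OC)cc4)ccc32)cc1` — in this assay: 30 nM.

Compound 2 carries the only real number shown in this assay; the other value is a limit (the limit of > 10000 nM in this assay, at which 1 of the 2 values shown sits). Within the data shown here, the single measured step, an at least 330-fold lower number from compound 1 to compound 2 (2.52 log units; beyond the scatter), concerns the group on the amide-type nitrogen in the ring. Compound 3 `COc1ccc(CN2C(=O)C(=O)c3cc(-c4cc(OC)cc(OC)c4)ccc32)cc1` differs from compound 2 elsewhere: 3,5-dimethoxyphenyl in place of 4-methoxyphenyl on an aromatic carbon. Among the measured compounds shown here, no measured step touches that position, so the step of a 1.7-fold higher number from compound 2 to compound 3 (0.22 log units; within the scatter) is expected to stay within the scatter. Compound 3 is therefore estimated at 50 nM, with a range from 10 nM to 300 nM.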

Compound 3, half-maximal inhibitory concentration: 510 nM
Estimate against measurement, compound 3: 10-fold (1.01 log units) below; the whole stated range lies below it.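

In this assay, among these compounds, the change to 3,5-dimethoxyphenyl on this aromatic carbon gives a 17-fold higher number from compound 2 to compound 3 (1.23 log units; beyond the scatter) and so shows that this position, which no earlier step touched, also responds strongly to substitution. The result separates the aryl group from the group on the amide-type nitrogen as a second place where a single change moves the number beyond the scatter. Nothing measured here gives a cause for this step.

The compounds shown do not tell whether the step follows from losing the 4-methoxyphenyl group or from the two methoxy groups of its replacement. As far as these compounds go, how a hydroxyl group, a fluorine atom or an amine on this phenyl ring would fare also stays open.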